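The compounds below may be only part of what the source reports. "The series", "measured", "known", "first", "only" and "open" are said of these compounds alone.

Compound 2 `CCNC(=O)Nc1c(OCCCn2cnc(-c3ccccc3)c2)cccc1N(C)C` carries the ethyl urea of the series. In an assay on aorta for inhibition of acyl-CoA:cholesterol acyltransferase (Oryctolagus cuniculus) (a lower number here means a stronger inhibitor, a higher number a weaker inhibitor), compound 2 gives > 10000 nM, which is a limit of the assay and not a number (the limit of > 10000 nM in this assay, at which 1 of the 2 values shown sits). Compound 3 `CCCNC(=O)Nc1c(OCCCn2cnc(-c3ccccc3)c2)cccc1N(C)C` differs from it by methyl in place of hydrogen on a saturated chain carbon, two bonds along the chain from an amide-type nitrogen. One measured step on this chain bears on the change: compound 1 `CCCCNC(=O)Nc1c(OCCCn2cnc(-c3ccccc3)c2)cccc1N(C)C` gives 810 nM in this assay, and the measured step reads an at least 12-fold higher number from compound 1 to compound 2 (1.09 log units; beyond the scatter). Restoring one carbon is therefore expected to lower the number, probably only part of the way. Compound 3 is expected near 3000 nM, between 1200 nM and 10000 nM. The expected step is an at least 3.3-fold lower number from compound 2 to compound 3 (0.52 log units; beyond the scatter).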

Compound 3, half-maximal inhibitory concentration: 7230 nM
Compound 3: the middle estimate sits 2.4-fold (0.38 log units) below what was measured; the range from low to high includes it.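

In this assay, removing only the terminal methyl from the chain of compound 1 already gives a change beyond the scatter: an 8.9-fold higher number from compound 1 to compound 3 (0.95 log units; beyond the scatter). The step on the shorter side, an at least 1.3-fold lower number from compound 2 to compound 3 (0.14 log units; that floor lies within the scatter), does not by itself establish a gain from the added methyl. The value of compound 2 is a limit of the assay: the limit of > 10000 nM in this assay, at which 1 of the 3 values shown sits.

Still open, on these data alone, is whether the number keeps falling with a chain longer than that of compound 1, such as hexyl, or with a cyclohexyl or phenyl group on the urea nitrogen.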